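This account rests on a few compounds, and the source may have more. Where it says the series, first, only, none or still open, it means among the compounds named here.

Compound 1 `CCCNc1cccc(NC(=O)c2ccc(OCCC)cc2)n1` gives 12600 nM in an in vitro assay on HEK-tsA201 cells for antagonist activity at Neuronal acetylcholine receptor; alpha3/beta4 (Homo sapiens), read by fluorescence and calcium flux; on this read-out higher numbers stand for weaker inhibition and lower numbers for stronger inhibition.
Compound 2 `CCCOc1ccc(C(=O)Nc2cccc(Nc3ccc(OC)cc3)n2)cc1` gives > 100000 nM in this assay, which is a limit of the assay and not a number.

Compound 2 therefore stands at the weak end of what is shown, at the limit of > 100000 nM in this assay, at which 1 of the 2 values shown sits, so the step of an at least 7.9-fold higher number from compound 1 to compound 2 (0.89 log units; beyond the scatter) is itself only a lower bound on the loss that came with 4-methoxyphenyl in place of propyl. Compound 3 `CCCOc1ccc(C(=O)Nc2cccc(NCc3ccccc3)n2)cc1` carries benzyl in place of 4-methoxyphenyl on a nitrogen on an aromatic ring. Going by the values given here, only the step from compound 1 to compound 2 bears on this change; benzyl, like propyl, attaches through a saturated carbon, yet keeps an aromatic ring as 4-methoxyphenyl does, so compound 3 is expected to sit somewhere within the span that the two measured compounds mark out. Compound 3 is estimated at 40000 nM, with a range of 10000 nM to 160000 nM. The expected step of an at least 2.5-fold lower number from compound 2 to compound 3 (0.39 log units; beyond the scatter) would bring the number back to a measurable value, though a limit again cannot be excluded.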

Compound 3, half-maximal inhibitory concentration: > 100000 nM
Compound 3: only a limit was reported (the forecaster's own chance of this, stated with the estimate: 35%); middle value at least 2.5-fold (0.39 log units) away from the limit.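

In this assay compound 3 gives > 100000 nM, which is again a limit of the assay and not a number. Moving the aromatic ring one saturated carbon away from the nitrogen therefore does not recover the activity of the propyl compound: the change gives an at least 7.9-fold higher number from compound 1 to compound 3 (0.89 log units; beyond the scatter), which, like the step to compound 2, is only a lower bound. The step between compound 2 and compound 3 cannot be read, and both compounds now sit together at the weak end of what is shown: the limit of > 100000 nM in this assay, at which 2 of the 3 values shown sit.

The compounds shown leave open whether a butyl chain or a cyclohexylmethyl group on this nitrogen would stay near compound 1 or also reach the limit. They also leave open whether a shorter chain such as ethyl, or a free amine, would give a lower number than compound 1.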